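Para-amino on the benzamide of compound 2

A few compounds are considered here, and "the series" means these few. Any claim that something is new, unique, unknown or untested is made for them only; others in the source may bear on it.

Measured so far:
- compound 1, `N#CN/C(=N\CCNC(=O)c1ccccc1[N+](=O)[O-])NCCCCOc1cccc(CN2CCCCC2)c1`: 7.52
- compound 2, `O=C(NCCCOc1cccc(CN2CCCCC2)c1)NCCNC(=O)c1ccccc1`: 6.1

In a functional assay on cardiac atrium for antagonist activity at histamine H2 receptor (Cavia porcellus) (on this read-out lower numbers stand for lower potency and higher numbers for higher potency (the scale is a negative logarithm)), compound 1 gives 7.52. In this assay compound 2 gives 6.1, the lowest of the two numbers; compound 1 lies above it by more than the usual scatter. The two compounds differ in several places at once, so the two values show only that gap and not what any single change does.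

Compound 3, `Nc1ccc(C(=O)NCCNC(=O)NCCCOc2cccc(CN3CCCCC3)c2)cc1`, is compound 2 with one change: amino in place of hydrogen on an aromatic carbon. Among the compounds with values here, no step between measured compounds isolates this kind of change, so nothing here tells whether it helps or hurts. A change of one atom at this position is expected to move the number little, most likely within the scatter, with no preferred direction. The expected step from compound 2 to compound 3 is a number 0.10 log units higher from compound 2 to compound 3 (within the scatter). Compound 3 is estimated at 6.2, within 5.5 to 6.9.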

Compound 3, negative logarithm of the antagonist equilibrium constant: 7.23
The estimate for compound 3 lay 1.03 log units below the measured number; the measured number lies above the stated range.
By their numbers in this assay, from the lowest: compound 2; then compounds 3 and 1 (each within the scatter of the next).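

In this assay, within the data shown here, the single change from phenyl to 4-aminophenyl gives a number 1.13 log units higher from compound 2 to compound 3 (beyond the scatter), so the read-out responds strongly to what sits on this aromatic carbon, para to a large group. Among these compounds, this is the first step here that isolates one change, and it shows that a group of a single heavy atom can, on its own, produce a large rise in potency. No independent measurement accompanies this result to explain the rise.

The compounds shown leave open whether a hydroxyl, a methoxy or a dimethylamino group on this same carbon would give a similar rise, or whether it is particular to the amino group. They also leave open whether an amino group on another carbon of this ring would have a comparable effect.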